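Cyclopropyl in Place of 1,3-Oxazol-4-yl: Half-Life Outlook

The source may hold more compounds than are shown below. What is called first, only, known or untested is meant among the compounds shown, and "the series" means these compounds.

Compound 1 `CCn1c(-c2cnc(C)nc2)nc2c(N[C@H]3CCN(C(=O)c4cocn4)C3)ncnc21`: 0.7 h
Compound 2 `CCn1c(-c2ccc(C(F)(F)F)nc2)nc2c(O[C@H]3CCN(C(=O)N4CC(OC)C4)C3)ncnc21`: 2 h
Compound 3 `CCn1c(-c2cnc(C)nc2)nc2c(O[C@H]3CCN(C(=O)C4CCOC4)C3)ncnc21`: 1.4 h

In an ADME assay (Rattus norvegicus, strain Wistar Han) for metabolic stability (on this read-out lower numbers stand for a shorter-lived compound and higher numbers for a longer-lived compound), compound 1 gives 0.7 h, the lowest of the three numbers. Compound 3 gives 1.4 h, which lies within the scatter of compound 1, while compound 2 gives 2 h, a gap beyond the scatter. Compound 4 `CCn1c(-c2cnc(C)nc2)nc2c(N[C@H]3CCN(C(=O)C4CC4)C3)ncnc21` shares the core of compound 1 and differs in one place: cyclopropyl in place of 1,3-oxazol-4-yl on a carbonyl carbon. Among the measured compounds shown here, no measured pair shows this exact change, so the size of its effect in this assay is unknown. With nothing pointing either way, the step from compound 1 to compound 4 is expected to stay within the scatter, perhaps a slight rise: a 1.4-fold higher number from compound 1 to compound 4 (0.15 log units; within the scatter). Compound 4 is therefore estimated at 1 h, with a likely range from 0.5 h to 2 h.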

Compound 4, half-life: 2.7 h
Estimate against measurement, compound 4: 2.7-fold (0.43 log units) below; the whole stated range lies below it.
By their numbers in this assay, from the lowest: compounds 1, 3, 2 and 4 (each within the scatter of the next, the first and the last beyond it).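

In this assay, the acyl group on the ring nitrogen proves able to shift the read-out on its own: cyclopropyl in place of 1,3-oxazol-4-yl gives a 3.9-fold higher number from compound 1 to compound 4 (0.59 log units; beyond the scatter), with the rest of the molecule unchanged. The earlier compounds shown here differ in more than one place, so they could not isolate this position. Nothing measured here explains the rise.

Going by these compounds, it remains open whether a methyl or a cyclobutyl group on the same carbonyl carbon would behave like cyclopropyl. On these data alone, whether the step carries over to other cores also remains open.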